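The source may report more compounds than this note shows. Statements on the series, on what has been measured and on what is new or still open speak of the compounds shown alone.

Of the compounds shown here, three have been measured in a functional assay on CHO cells for antagonist activity at metabotropic glutamate receptor 5 (Homo sapiens), read by calcium flux; on this read-out higher numbers stand for weaker inhibition and lower numbers for stronger inhibition. Compound 1 `Cc1c(C(C)OC(=O)NC2CCCCC2)oc2ncnn12` gives 3160 nM; compound 2 `Cc1c(C(C)OC(=O)Nc2ccccc2Cl)oc2ncnn12` gives 501 nM; compound 3 `Cc1c(C(C)OC(=O)Nc2ccc(Cl)cc2)oc2ncnn12` gives 2510 nM. On these numbers compound 3 stands second highest of the three, close to compound 1 and well apart from compound 2: a 1.3-fold lower number from compound 1 to compound 3 (0.10 log units; within the scatter), whereas a 5.0-fold higher number from compound 2 to compound 3 (0.70 log units; beyond the scatter). Compound 4 `Cc1c(C(C)OC(=O)Nc2cccc(F)c2)oc2ncnn12` has not been measured; it differs from compound 3 in one place: 3-fluorophenyl in place of 4-chlorophenyl on an amide-type nitrogen. For the measured compounds named here, no measured step swaps one halogen-bearing phenyl for another in this way, so the bearing of the existing steps is indirect. The step of a 6.3-fold lower number from compound 1 to compound 2 (0.80 log units; beyond the scatter) and the step of a 5.0-fold higher number from compound 2 to compound 3 (0.70 log units; beyond the scatter) show that moving a chlorine around the phenyl ring can shift the number by a modest amount in either direction, while a 1.3-fold lower number from compound 1 to compound 3 (0.10 log units; within the scatter) shows that not every change at this nitrogen moves it beyond the scatter. For compound 4 a number close to that of compound 3, or somewhat lower, is therefore expected in this assay, with the step of a 1.7-fold lower number from compound 3 to compound 4 (0.22 log units; within the scatter). The estimate for compound 4 is 1500 nM, expected to fall between 400 nM and 5000 nM.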

Compound 4, half-maximal inhibitory concentration: 50.1 nM
For compound 4 the middle estimate is 30-fold (1.48 log units) above the measured one; measured number below the stated range.
By their numbers in this assay, from the lowest: compound 4; then compound 2; then compounds 3 and 1 (each within the scatter of the next).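

For the compounds shown here, the group on this amide-type nitrogen matters far more than the earlier compounds showed: replacing one halogen-bearing phenyl with another of the same heavy-atom count gives a 50-fold lower number from compound 3 to compound 4 (1.70 log units; beyond the scatter), a larger step than any seen before. The other two gaps are also beyond the scatter, at a 10-fold lower number from compound 2 to compound 4 (1.00 log units; beyond the scatter) and a 63-fold lower number from compound 1 to compound 4 (1.80 log units; beyond the scatter), so the 3-fluorophenyl compound is the strongest inhibitor of the four in this assay. Nothing measured here accounts for this jump.

This step swaps the halogen and changes where it sits on the ring at once, so the compounds shown cannot tell which of the two matters. A 3-chlorophenyl or 4-fluorophenyl group on this nitrogen would pull the two apart, and a plain phenyl group would show what the halogen adds at all.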